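The source may hold more compounds than are shown below. What is called first, only, known or untested is meant among the compounds shown, and "the series" means these compounds.

In an ADME assay on microsomes from liver (Mus musculus) for metabolic stability, read by LC-MS (on this read-out higher numbers stand for a longer-lived compound and lower numbers for a shorter-lived compound), compound 1 `O=C(Nc1ccc(F)c(-c2nc3ncc(-c4ccc(F)cc4)cc3[nH]2)c1)N1CCCC1` gives 0.095 h as its half-life. Compound 2 `O=C(Nc1ccc(F)c(-c2nc3ncc(-c4cccnc4F)cc3[nH]2)c1)N1CCCC1` gives > 1.5 h as a limit of the assay and not a number, so it stands at that limit of > 1.5 h in this assay, at which 1 of the 2 values shown sits, with no exact figure. For the measured compounds named here, the only measured step, an at least 15-fold higher number from compound 1 to compound 2 (1.19 log units; beyond the scatter), is large. Compound 3 `O=C(Nc1ccc(F)c(-c2nc3ncc(-c4cccc(F)c4)cc3[nH]2)c1)N1CCCC1` has 3-fluorophenyl in place of 2-fluoropyridin-3-yl on an aromatic carbon and so, like compound 1, carries a fluorophenyl group. A large fall in this assay is therefore expected, resting on the size of an at least 15-fold higher number from compound 1 to compound 2 (1.19 log units; beyond the scatter) in reverse. The expected change is an at least 10-fold lower number from compound 2 to compound 3 (1.00 log units; beyond the scatter) in this read-out. The estimate for compound 3 is 0.15 h, with an expected range from 0.06 h to 0.5 h in all.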

Compound 3, half-life: 0.0833 h
Compound 3: the middle estimate sits 1.8-fold (0.26 log units) above what was measured, within the range that was stated.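

In this assay, the fall seen on leaving the 2-fluoropyridin-3-yl group, an at least 18-fold lower number from compound 2 to compound 3 (1.25 log units; beyond the scatter), appears with a second fluorophenyl group, so the earlier large step is not tied to 4-fluorophenyl alone. The two fluorophenyl groups cannot be told apart at this position: a 1.1-fold lower number from compound 1 to compound 3 (0.06 log units; within the scatter). Compound 2 stands at a limit of the assay and not a number, so the full size of its step stays unknown: the limit of > 1.5 h in this assay, at which 1 of the 3 values shown sits.

Whether the ring nitrogen alone accounts for the gap stays open. A pyridin-3-yl group without fluorine at this position would bear on that.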